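Hydroxyphenyl position on two dienone cores in A549 cells

This account rests on a few compounds, and the source may have more. Where it says the series, first, only, none or still open, it means among the compounds named here.

Measured in a functional assay on A549 cells (Homo sapiens) for cytotoxicity, read by MTT assay, with a stated time of 72 h; on this read-out lower numbers stand for stronger inhibition and higher numbers for weaker inhibition:
- compound 1 `COc1cccc(/C=C2\CCC/C(=C\c3cccc(O)c3)C2=O)c1OC`: > 20000 nM, a limit of the assay
- compound 2 `COc1cccc(/C=C2\CCC/C(=C\c3ccc(O)cc3)C2=O)c1OC`: > 20000 nM, a limit of the assay
- compound 3 `COc1ccc(/C=C2\CCC/C(=C\c3cccc(O)c3)C2=O)cc1OC`: 4300 nM

Compound 1 and compound 2 share one core and differ by 4-hydroxyphenyl in place of 3-hydroxyphenyl on a double-bonded chain carbon bound to a double-bonded ring carbon. Both sit at the limit (the limit of > 20000 nM in this assay, at which 2 of the 3 values shown sit), so the step that the two limits leave unreadable from compound 1 to compound 2 has no readable size. Compound 3 carries a second core; how the two cores differ is not broken down here. Compound 4 `COc1ccc(/C=C2\CCC/C(=C\c3ccc(O)cc3)C2=O)cc1OC` repeats the same kind of change on the core of compound 3: 4-hydroxyphenyl in place of 3-hydroxyphenyl on a double-bonded chain carbon bound to a double-bonded ring carbon. Because compound 3 gives 4300 nM, a number rather than a limit, the step to compound 4 can become readable. Among the measured compounds shown here, the expected step of a 1.1-fold lower number from compound 3 to compound 4 (0.03 log units; within the scatter) is estimated as small, since the only measured instance of this change, from compound 1 to compound 2, shows nothing beyond the limits. Compound 4 is therefore estimated at 4000 nM in this assay, with the range 1500 nM to 15000 nM.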

Compound 4, half-maximal inhibitory concentration: > 20000 nM
Compound 4: no number, only a limit (the forecaster's own chance of this, stated with the estimate: 15%); middle value at least 5.0-fold (0.69 log units) away from the limit.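

On the core of compound 3, 4-hydroxyphenyl in place of 3-hydroxyphenyl gives an at least 4.6-fold higher number from compound 3 to compound 4 (0.66 log units; beyond the scatter) in this assay. Compound 4 gives only a limit of the assay, not a number, so this step has a lower bound but no exact size. The same change on the core of compound 1 cannot be read, so these data neither confirm nor rule out that the change behaves alike on both cores, because most values sit at one limit: the limit of > 20000 nM in this assay, at which 3 of the 4 values shown sit.

The compounds shown carry only hydroxyphenyl groups at this place. On these data alone, whether an aminophenyl or a carboxyphenyl group there would keep the activity of compound 3 remains open.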